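A Second Fluorine on the Aryl Ring of Compound 2

The compounds below may be only part of what the source reports. "The series", "measured", "known", "first", "only" and "open" are said of these compounds alone.

Of the compounds shown here, two have so far been tested in an in vitro assay on HEK385-7 cells for displacement of a labelled ligand from prostaglandin D2 receptor 2 (Homo sapiens); on this read-out lower numbers stand for stronger inhibition and higher numbers for weaker inhibition. Compound 1 `O=C(O)Cc1sc(C(c2ccccc2)c2ccccc2)nc1-c1ccccc1` gives 570 nM. Compound 2 `O=C(O)Cc1sc(C(c2ccccc2)c2ccccc2)nc1-c1cccc(F)c1`, which differs from it by a fluoro in place of a hydrogen on an aromatic carbon, gives 2.9 nM. Among the compounds with values here, the single measured step is a 200-fold lower number from compound 1 to compound 2 (2.29 log units; beyond the scatter), so compound 2 stands as the lower of the two numbers, and the nearest neighbour, compound 1, sits higher by exactly that step.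

Compound 3 `O=C(O)Cc1sc(C(c2ccccc2)c2ccccc2)nc1-c1ccc(F)c(F)c1` has not yet been measured in this assay. It differs from compound 2 by fluoro in place of hydrogen on an aromatic carbon. The new fluoro sits on an aromatic carbon of the same six-membered carbon ring, ortho to the fluoro group already present and para to a large group; read one bond further out, a 3-fluorophenyl becomes a 3,4-difluorophenyl. Within the data shown here, the only step that bears on this change, a 200-fold lower number from compound 1 to compound 2 (2.29 log units; beyond the scatter), describes the first fluoro entering a ring that had none. Among the measured compounds shown here, no measured pair shows what a second fluoro adds. A further large drop is therefore not expected; the expected step is a 1.0-fold higher number from compound 2 to compound 3 (0.01 log units; within the scatter), which stays within the scatter. Compound 3 is expected to give about 3 nM in this assay, with a range from 1 nM to 10 nM.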

Compound 3, half-maximal inhibitory concentration: 4.1 nM
Compound 3: middle estimate off by 1.4-fold (0.14 log units), on the low side; low and high end bracket the measured number.
By their numbers in this assay, from the lowest: compounds 2 and 3 (each within the scatter of the next); then compound 1.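

In this assay the ring that already carries one fluoro takes a second at the carbon ortho to it and para to a large group, and the step is a 1.4-fold higher number from compound 2 to compound 3 (0.15 log units; within the scatter) and so cannot be told apart from no change at all. This adds what compound 2 alone could not show: the first fluoro's large effect does not depend on this neighbouring carbon keeping its hydrogen, and the 3,4-difluorophenyl still holds a step of a 140-fold lower number from compound 1 to compound 3 (2.14 log units; beyond the scatter) over the plain phenyl. Nothing measured here explains why the first fluoro matters so much while the second makes no readable difference. 

Whether a chloro, a methyl or a methoxy on the same carbon would also leave the number within the scatter of compound 2 stays open, since fluoro is the only group shown at this position. Also open, from the compounds shown here alone, is whether a nitrile or a trifluoromethyl there would behave the same way, and so whether this carbon accepts groups in general or only a single fluorine atom.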